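Capping the hydroxy group of compound 2 with methyl

This account rests on a few compounds, and the source may have more. Where it says the series, first, only, none or still open, it means among the compounds named here.

Measured in a functional assay on MCF7 cells (Homo sapiens) for inhibition, read by sulforhodamine B assay; a lower number here means a stronger inhibitor of growth, a higher number a weaker inhibitor of growth:
Compound 1 `Oc1cccc2[nH]c(-c3ccc(-c4ccc(-c5ccccc5)cc4)cc3)nc12` gives 2200 nM
Compound 2 `Oc1ccc(-c2ccc(-c3ccc(-c4nc5c(O)cccc5[nH]4)cc3)cc2)cc1` gives 190 nM

Of the two, compound 2 has the lower number and is the stronger inhibitor of growth, by a margin beyond the scatter. Within the data shown here, the only measured step, a 12-fold lower number from compound 1 to compound 2 (1.06 log units; beyond the scatter), is large and comes with hydroxy in place of hydrogen on an aromatic carbon.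

Compound 3 `COc1ccc(-c2ccc(-c3ccc(-c4nc5c(O)cccc5[nH]4)cc3)cc2)cc1` has not yet been measured. It differs from compound 2 at that same hydroxy: methyl in place of hydrogen on an oxygen on an aromatic ring, with methyl in place of hydrogen on an oxygen on an aromatic ring, so that 4-hydroxyphenyl becomes 4-methoxyphenyl. Among the measured compounds shown here, no measured step covers this exact change, and the one available bears on it only indirectly. Compound 3 keeps the oxygen gained in that step but not its hydrogen, so part of the gain may be expected to be lost, with the number rising in this assay by less than the earlier step.

The expected step is a 2.2-fold higher number from compound 2 to compound 3 (0.34 log units; beyond the scatter). For compound 3 the estimated value is 420 nM, with an expected range from 130 nM to 1400 nM.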

Compound 3, concentration for 50% growth inhibition: 3110 nM
The estimate for compound 3 lay 7.4-fold (0.87 log units) below the measured number; the whole stated range lies below it.
By their numbers in this assay, from the lowest: compound 2; then compounds 1 and 3 (each within the scatter of the next).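

In this assay the hydrogen on this oxygen turns out to matter as much as the oxygen itself, since the change from 4-hydroxyphenyl to 4-methoxyphenyl gives a 16-fold higher number from compound 2 to compound 3 (1.21 log units; beyond the scatter) and is large. Measured against the compound with only hydrogen at this place, the methoxy compound shows a 1.4-fold higher number from compound 1 to compound 3 (0.15 log units; within the scatter) and so keeps nothing measurable of the gain seen with hydroxy. Across these three compounds, then, the lower number goes with the free hydroxy alone, not with an oxygen at this place as such, and no measurement shown explains why the methyl cap has this effect.

From the compounds shown here alone, it remains open whether an amine or a carboxylic acid at this place would match the hydroxy in this growth read-out, or whether any group other than hydroxy could keep the number of compound 2. Also open, going by these compounds, is whether a longer chain on this oxygen, such as ethoxy in place of methoxy, would stay within the scatter of compound 3 or move away from it.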